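Replacing a Long Chain with a Hydroxy Group

The source may hold more compounds than are shown below. What is called first, only, known or untested is meant among the compounds shown, and "the series" means these compounds.

Compound 1 `CCCCCCCc1cn(C(c2ccccc2)c2cc3cc(Br)ccc3nc2OC)nn1` gives 9.7% in an ADME assay on HeLa cells (Homo sapiens) for cytotoxicity, read by sulforhodamine B assay, with a stated time of 48 h, tested at 10 uM; on this read-out lower numbers stand for less inhibition and higher numbers for more inhibition at the one concentration tested (going by the name of the read-out).
Compound 2 `COc1nc2ccc(Br)cc2cc1C(c1ccccc1)n1cc(-c2ccccc2)nn1` gives 13.9% in this assay.
Compound 3 `CCCCCCCCc1cn(C(c2ccccc2)c2cc3cc(Br)ccc3nc2OC)nn1` gives 0.1% in this assay.

Compound 3 stands lowest of the three numbers. Its nearest neighbour is compound 1, reached by a step of a number 9.6 percentage points lower from compound 1 to compound 3 (within the scatter), and its furthest is compound 2, reached by a step of a number 13.8 percentage points lower from compound 2 to compound 3 (beyond the scatter). Between the other two the step is a number 4.2 percentage points higher from compound 1 to compound 2 (within the scatter). All three measured compounds share one core and differ only in the group on the same aromatic carbon.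

Compound 4 `COc1nc2ccc(Br)cc2cc1C(c1ccccc1)n1cc(CCO)nn1` is the next member. It differs from compound 3 in that (hydroxy in place of hexyl on a saturated chain carbon, two bonds along the chain from an aromatic carbon). The measured steps that bear on it are the ones that alter that same chain: a number 9.6 percentage points lower from compound 1 to compound 3 (within the scatter) adds a single carbon at the far end, and a number 13.8 percentage points lower from compound 2 to compound 3 (beyond the scatter) exchanges a phenyl for the octyl. Neither step replaces most of the chain by a hydroxy group, so none matches the change directly. Both steps were small, and all three measured values sit in a narrow low band, so a step of a number 7.9 percentage points higher from compound 3 to compound 4 (within the scatter) is expected, not beyond the scatter. Compound 4 is therefore estimated at 8%, between 0% and 22%.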

Compound 4, a percentage reported as inhibition, at one concentration (the size of the read-out at that concentration, not a potency): 0.85%
For compound 4 the middle estimate is 7.2 percentage points above the measured one; the measured number falls inside the stated range.
By their numbers in this assay, from the lowest: compounds 3, 4, 1 and 2 (each within the scatter of the next, the first and the last beyond it).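

Among these compounds, compound 4 is the first of the series to carry a hydroxy on this chain, and a number 0.8 percentage points higher from compound 3 to compound 4 (within the scatter) in this assay shows that swapping hexyl for hydroxy, which removes six carbons and adds one hydrogen-bond donor and one acceptor, gives a change that stays within the scatter. The same holds for hydroxy in place of pentyl, with a number 8.9 percentage points lower from compound 1 to compound 4 (within the scatter) as the printed step, so at this position the read-out does not separate the 2-hydroxyethyl group from the heptyl or octyl chains. Against phenyl the 2-hydroxyethyl group does stand apart, with a number 13.1 percentage points lower from compound 2 to compound 4 (beyond the scatter) beyond the scatter, much as octyl does, although heptyl in compound 1 goes against any clean split between phenyl and the chains, and no measurement offered here accounts for any of these numbers.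

The compounds shown leave open whether an amine or a carboxylic acid in place of the hydroxy on this chain, or a hydroxy carried at the end of a longer chain, would read any differently in this assay from the low values seen so far. They also leave open whether a substituted phenyl, such as a methoxyphenyl, would move the number further from that of compound 4 than the plain phenyl of compound 2 does.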